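The source may report more compounds than this note shows. Statements on the series, on what has been measured and on what is new or still open speak of the compounds shown alone.

In a functional assay on the whole organism (strain Sprague-Dawley) for inhibition, with Rattus norvegicus as the target (on this read-out lower numbers stand for an effect already at smaller amounts and higher numbers for an effect only at larger amounts of compound), compound 1 `O=c1c(-c2nn[nH]n2)c[nH]c2c(F)cccc12` gives 0.625 mg/kg and compound 2 `CC(C)c1cccc2c(=O)c(-c3nn[nH]n3)c[nH]c12` gives 1.25 mg/kg. Within the data shown here, compound 2 has the higher of the two numbers, yet the only measured step, a 2.0-fold higher number from compound 1 to compound 2 (0.30 log units; within the scatter), lies within the scatter, so the two compounds cannot be set in order. Compound 3 `CS(=O)(=O)c1cccc2c(=O)c(-c3nn[nH]n3)c[nH]c12` differs from compound 2 by methylsulfonyl in place of isopropyl on an aromatic carbon. Among the measured compounds shown here, no measured step bears directly on this change: the one step in hand replaces fluoro by isopropyl on the same aromatic carbon and stays within the scatter, so it shows only that this carbon tolerates a change of substituent without a shift beyond the scatter in this assay. Methylsulfonyl has not been tried, and a step in either direction is possible, but on the evidence no step beyond the scatter is expected, and the estimate for compound 3 is no change at the digits printed from compound 2 to compound 3 (within the scatter). Compound 3 is therefore expected to give 1.25 mg/kg, within a range from 0.4 mg/kg to 4 mg/kg.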

Compound 3, minimum effective dose: 10 mg/kg
Beside the measured number, compound 3's estimate is 8.0-fold (0.90 log units) below it; measured number outside the range, above it.
By their numbers in this assay, from the lowest: compounds 1 and 2 (each within the scatter of the next); then compound 3.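

In this assay this aromatic carbon proves not to be indifferent to its substituent: methylsulfonyl in place of isopropyl gives an 8.0-fold higher number from compound 2 to compound 3 (0.90 log units; beyond the scatter) and methylsulfonyl in place of fluoro gives a 16-fold higher number from compound 1 to compound 3 (1.20 log units; beyond the scatter) on the same carbon. Where fluoro and isopropyl could not be set in order, methylsulfonyl separates itself from both, towards an effect only at larger doses, so the tolerance suggested by the earlier pair does not extend to every group here. Nothing available accounts for this shift.

On these data alone, whether the loss belongs to methylsulfonyl alone or would also appear with other groups on this carbon remains open; an amine, a carboxylic acid or a methoxy group would help to show this. As far as these compounds go, it is equally open whether a smaller sulfur-bearing group, such as methylthio, would stay with compound 1 and compound 2 or move with compound 3.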